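The compounds below may be only part of what the source reports. "The series", "measured", "known", "first", "only" and "open" are said of these compounds alone.

Compound 1 `Cn1cc(C2=C(c3nn(CCn4ccnc4)c4ncccc34)C(=O)NC2=O)c2ccccc21`: in a functional assay on SMMC-7721 cells (Homo sapiens) for antiproliferative activity, read by MTT assay, with a stated time of 48 h (on this read-out lower numbers stand for stronger inhibition and higher numbers for weaker inhibition), compound 1 gives > 100000 nM, which is a limit of the assay.
Compound 2 `CN(C)CCCn1nc(C2=C(c3cn(C)c4ccccc34)C(=O)NC2=O)c2cccnc21`: in this assay compound 2 gives > 100000 nM, also a limit.
Compound 3 `Cn1cc(C2=C(c3nn(CCCN4CCCCC4)c4ncccc34)C(=O)N(c3ccccn3)C2=O)c2ccccc21`: in this assay compound 3 gives > 100000 nM, again a limit.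

Compound 3 thus stands where every measured compound in this set stands: the limit of > 100000 nM in this assay, at which 3 of the 3 values shown sit. No number separates it from compound 1 or compound 2, and nothing in the shown data places it above or below either of them.

Among the measured compounds shown here, the only measured step, a step that the two limits leave unreadable from compound 1 to compound 2, concerns the chain carried on the ring nitrogen, not the amide-type nitrogen in the ring, and its size cannot be read. The change from compound 3 to compound 4 `Cn1cc(C2=C(c3nn(CCCN4CCCCC4)c4ncccc34)C(=O)N(c3ccc(Cl)cc3)C2=O)c2ccccc21` is 4-chlorophenyl in place of pyridin-2-yl on an amide-type nitrogen in a ring. No measured pair touches this position, so no step bears on the change and its size cannot be anticipated from the shown data.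

Given that (the limit of > 100000 nM in this assay, at which 3 of the 3 values shown sit), compound 4 is expected to sit at or near the same limit. Its value in this assay is estimated at 100000 nM, with a range from 20000 nM to 300000 nM. The step from compound 3 to compound 4 is therefore expected to be a number no higher from compound 3 to compound 4 (the limit leaves the size open), none beyond the scatter.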

Compound 4, half-maximal inhibitory concentration: > 100000 nM
Compound 4 was reported as a limit (the forecaster's own chance of this, stated with the estimate: 65%); the middle value lies on the limit itself.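

Compound 3 and compound 4 both stand at a limit in this assay, so no size can be read for the change to 4-chlorophenyl in place of pyridin-2-yl: the limit of > 100000 nM in this assay, at which 4 of the 4 values shown sit.

The compounds shown leave open how they rank against one another, and whether any group on the amide-type nitrogen in a ring would give a readable value in this assay.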